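This account rests on a few compounds, and the source may have more. Where it says the series, first, only, none or still open, it means among the compounds named here.

Compound 1, `CC(C)(C)OC(=O)C(O)Cn1cnc2c(N)ncnc21`, is the starting point of this account. In a functional assay on Vero cells (Chlorocebus sabaeus) for cytotoxicity (on this read-out higher numbers stand for lower toxicity in this test and lower numbers for higher toxicity in this test), compound 1 gives > 400 ug/mL, which is a limit of the assay and not a number, as recorded by the limit of > 400 ug/mL in this assay, at which 1 of the 3 values shown sits. Two measured neighbours differ from compound 1 only in the group on an oxygen next to a carbonyl group. Compound 2, `Nc1ncnc2c1ncn2CC(O)C(=O)OCc1ccco1`, gives 40 ug/mL in this assay, and the step shows an at least 10-fold lower number from compound 1 to compound 2 (1.00 log units; beyond the scatter). Compound 3, `CCCCCOC(=O)C(O)Cn1cnc2c(N)ncnc21`, gives 200 ug/mL, the step from compound 1 being an at least 2.0-fold lower number from compound 1 to compound 3 (0.30 log units; that floor lies within the scatter); between the two neighbours the step reads a 5.0-fold higher number from compound 2 to compound 3 (0.70 log units; beyond the scatter). Compound 4, `COC(=O)C(O)Cn1cnc2c(N)ncnc21`, has not yet been measured in this assay. It differs from compound 1 by methyl in place of tert-butyl on an oxygen next to a carbonyl group. Both measured steps from compound 1 replaced tert-butyl with a larger group and moved the number downward, the one with (furan-2-yl)methyl well beyond the scatter, the one with pentyl only at the edge of it. Among the compounds with values here, no measured step replaces tert-butyl with a smaller group, so the direction for compound 4 rests on the starting limit alone. Compound 4 is therefore expected to stay near the limit, with a step of a number no higher from compound 1 to compound 4 (the limit leaves the size open). The estimate for compound 4 is 400 ug/mL, with a range from 100 ug/mL to 800 ug/mL.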

Compound 4, minimum cytotoxic concentration: > 400 ug/mL
Compound 4 was reported as a limit; the forecaster's own chance of this, stated with the estimate: 50%; the middle value sits exactly at the limit.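

Methyl is the first group at this oxygen that is smaller than tert-butyl, and in this assay it leaves the compound at the same limit as tert-butyl, so the two compounds cannot be told apart at this end of the series. Compound 1 and compound 4 both carry a limit of the assay and not a number, and the step between them cannot be read because of that shared limit: the limit of > 400 ug/mL in this assay, at which 2 of the 4 values shown sit. Against the larger groups, the result separates the two earlier neighbours: the change from (furan-2-yl)methyl to methyl gives an at least 10-fold higher number from compound 2 to compound 4 (1.00 log units; beyond the scatter), while the change from pentyl to methyl gives an at least 2.0-fold higher number from compound 3 to compound 4 (0.30 log units; that floor lies within the scatter), so among these four compounds only (furan-2-yl)methyl stands clearly apart.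

From the compounds shown here alone, how far compound 1 and compound 4 lie from that limit stays open, as does whether any difference exists between them. The compounds shown also leave open whether the lower number of compound 2 belongs to furan-2-yl in particular or would also come with a benzyl group or a longer chain such as octyl, and what a free carboxylic acid would give at this place.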